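The source may hold more compounds than are shown below. What is called first, only, known or untested is meant among the compounds shown, and "the series" means these compounds.

Measured so far:
compound 1 `CCC(=O)Nc1sc2c(c1C#N)CCCC2`: 12000 nM
compound 2 `N#Cc1c(NC(=O)C2CC2)sc2c1CCCC2`: 2700 nM
compound 3 `N#Cc1c(NC(=O)C2CCCC2)sc2c1CCCC2`: 470 nM

These three compounds were tested in a functional assay on RKE cells for antagonist activity at Vasoactive intestinal polypeptide receptor 1 (Rattus norvegicus), read by HTRF and cAMP accumulation, with stated times of 10 min and 30 min; on this read-out lower numbers stand for stronger inhibition and higher numbers for weaker inhibition. Compound 1 gives the highest of the three numbers, so on this read-out it is the weakest of the set. Its nearest neighbour is compound 2, reached by a 4.4-fold lower number from compound 1 to compound 2 (0.65 log units; beyond the scatter), and the furthest is compound 3, reached by a 26-fold lower number from compound 1 to compound 3 (1.41 log units; beyond the scatter). Between the two ring-bearing compounds there is a 5.7-fold lower number from compound 2 to compound 3 (0.76 log units; beyond the scatter). Each measured step swaps the group on the carbonyl carbon for a ring and lowers the number.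

Compound 4 `Cc1cccc(CCC(=O)Nc2sc3c(c2C#N)CCCC3)c1` has not yet been measured in this assay. It differs from compound 1 by 3-methylphenyl in place of hydrogen on a saturated chain carbon, two bonds along the chain from a carbonyl carbon. For the measured compounds named here, no measured step makes exactly this change: the added ring sits two bonds along the chain from the carbonyl carbon, not on the carbonyl carbon itself. Still, every enlargement of that side chain seen so far lowered the number, as in a 4.4-fold lower number from compound 1 to compound 2 (0.65 log units; beyond the scatter) and a 26-fold lower number from compound 1 to compound 3 (1.41 log units; beyond the scatter), so a modest lowering is expected here too. For compound 4 the expected result is 1500 nM, within the range 300 nM to 8000 nM. This estimate means a step of an 8.0-fold lower number from compound 1 to compound 4 (0.90 log units; beyond the scatter).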

Compound 4, half-maximal inhibitory concentration: 750 nM
Beside the measured number, compound 4's estimate is 2.0-fold (0.30 log units) above it, within the range that was stated.
By their numbers in this assay, from the lowest: compounds 3 and 4 (each within the scatter of the next); then compound 2; then compound 1.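

In this assay, 3-methylphenyl on a saturated chain carbon, two bonds along the chain from a carbonyl carbon, gives a 16-fold lower number from compound 1 to compound 4 (1.20 log units; beyond the scatter) and so counts as a large step. For the compounds shown here, the earlier compounds changed only the group on the carbonyl carbon itself and carried no aromatic ring, so this result is the first to show that a six-membered aromatic ring further along the chain is compatible with a much lower number. No measurement given here explains why this change lowers the number.

The compounds shown leave open how much of this step comes from the ring and how much from its methyl, which a plain phenyl at the same chain carbon would help to separate. They also leave open how a longer chain before the ring, or an amine in place of the methyl, would affect the number.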